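The source may hold more compounds than are shown below. What is called first, only, known or untested is meant among the compounds shown, and "the series" means these compounds.

The three compounds measured share one core and differ only in the aryl group attached to it. Compound 1 `COc1ccc(Cl)cc1-n1ncc(-c2nnc(-c3ccc(Br)c(C)c3)o2)c1C` gives 5.2 in a physicochemical assay for lipophilicity, using the shake flask method, measured as octanol-water partition; a higher number here means a more lipophilic compound, a lower number a more polar compound. Compound 2 `COc1ccc(Cl)cc1-n1ncc(-c2nnc(-c3cc(Cl)cc(Cl)c3)o2)c1C` gives 5.61 in this assay, and compound 3 `COc1ccc(Cl)cc1-n1ncc(-c2nnc(-c3ccccc3)o2)c1C` gives 4.32. Compound 3 thus stands lowest of the three: the step of a number 0.88 log units lower from compound 1 to compound 3 (beyond the scatter) and the step of a number 1.29 log units lower from compound 2 to compound 3 (beyond the scatter) both run downward into it, and both lie beyond the scatter.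

Compound 4 `COc1ccc(Cl)cc1-n1ncc(-c2nnc(-c3ccc(Cl)cc3)o2)c1C` is not yet measured. Its difference from compound 3 is chloro in place of hydrogen on an aromatic carbon, on an aromatic carbon of a six-membered aromatic ring of carbon only, para to a large group; read one bond further out, phenyl becomes 4-chlorophenyl. The measured steps bearing on this are the replacement of the bare phenyl by two halogen-bearing aryl groups, which raised the reading by modest to large amounts. A single chloro is expected to bring a smaller rise than either of those pairs of substituents did, so the expected step is a number 0.68 log units higher from compound 3 to compound 4 (beyond the scatter) in this assay. Compound 4 is therefore expected to give about 5, within 4.7 to 5.3.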

Compound 4, partition coefficient: 4.51
Compound 4: middle estimate off by 0.49 log units, on the high side; the measured number lies below the stated range.
By their numbers in this assay, from the lowest: compounds 3 and 4 (each within the scatter of the next); then compound 1; then compound 2.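

The step for chloro in place of hydrogen, on an aromatic carbon para to a large group, is a number 0.19 log units higher from compound 3 to compound 4 (within the scatter), so in this assay this single change does not separate the two compounds. The 4-chlorophenyl group does not match the two more heavily substituted aryl groups, with a number 1.10 log units lower from compound 2 to compound 4 (beyond the scatter) and a number 0.69 log units lower from compound 1 to compound 4 (beyond the scatter), which shows that one chloro at this position does not reproduce the larger rises seen earlier from the bare phenyl. Nothing measured here accounts for how small the chloro step is.

The compounds shown leave open which of the extra groups, the second chloro, the bromo or the methyl, carries those larger differences. They also leave open where an amine or a carboxylic acid on this same carbon would place the reading.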